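This account rests on a few compounds, and the source may have more. Where it says the series, first, only, none or still open, it means among the compounds named here.

Compounds measured so far:

compound 1 `CN1CCCC(Cn2ccccc2=O)C1` — 160000 nM
compound 2 `O=c1ccccn1CC1CCCN(Cc2ccccc2)C1` — 83000 nM
compound 3 `O=c1ccccn1CC1CCNCC1` — 750000 nM

In an assay on HEK293 cells for displacement of a labelled ligand from Neuronal acetylcholine receptor; alpha3/beta4 (Rattus norvegicus), tested at 10 uM (on this read-out higher numbers stand for weaker inhibition and lower numbers for stronger inhibition), compound 3 stands with the highest number of the three, beyond the scatter from both compound 1 and compound 2, and is thus the weakest binder in this set. Compound 4 `O=c1ccccn1CC1CCN(Cc2ccccc2)CC1` differs from compound 3 in one place: benzyl in place of hydrogen on an amine nitrogen in a ring. Within the data shown here, the one measured step that bears on this change is a 1.9-fold lower number from compound 1 to compound 2 (0.29 log units; within the scatter), where a phenyl was added to the carbon that carries the ring nitrogen of compound 1; that step stayed within the scatter. Compound 4 likewise gains a benzyl on the ring amine nitrogen of compound 3, so a step of similar size, if any, is expected in this assay, toward a somewhat lower number but not clearly beyond the scatter. The expected step is a 1.9-fold lower number from compound 3 to compound 4 (0.27 log units; within the scatter). Compound 4 is therefore estimated at 400000 nM, with a likely range from 150000 nM to 1000000 nM.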

Compound 4, inhibition constant: 620000 nM
The estimate for compound 4 lay 1.6-fold (0.19 log units) below the measured number; measured number inside the range.
By their numbers in this assay, from the lowest: compounds 2 and 1 (each within the scatter of the next); then compounds 4 and 3 (each within the scatter of the next).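

In this assay the change from hydrogen to benzyl on the amine nitrogen gives a 1.2-fold lower number from compound 3 to compound 4 (0.08 log units; within the scatter) and so does not separate the two compounds. The earlier step of a 1.9-fold lower number from compound 1 to compound 2 (0.29 log units; within the scatter) came from a phenyl added to a methyl group already on the ring nitrogen, whereas this result tests the benzyl directly against hydrogen, three ring bonds from the ring atom that bears a group of 8 heavy atoms. No supporting data are available to explain this result.

The compounds shown leave open whether a different group on this nitrogen, such as an acetyl group, a phenethyl chain or a chain ending in a carboxylic acid, would move the number beyond the scatter. They also leave open whether a substituent on the benzyl ring would do so.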